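The source may report more compounds than this note shows. Statements on the series, on what has been measured and on what is new or still open speak of the compounds shown alone.

Compound 1, with the structure `CCOC(=O)CNc1nc(Nc2ccccc2)ncc1[N+](=O)[O-]`, is the starting point. In a functional assay on MDA-MB-231 cells (Homo sapiens) for antiproliferative activity, read by MTT assay, with a stated time of 48 h (on this read-out higher numbers stand for weaker inhibition and lower numbers for stronger inhibition), compound 1 gives 54300 nM. Among the three compounds measured so far, compound 1 is the only one with an actual number; the other two values are limits of the assay. Compound 2, with the structure `COC(=O)CN(C)c1nc(Nc2ccccc2)ncc1[N+](=O)[O-]`, reaches only a limit in this assay, where compound 2 gives > 100000 nM. Compound 3, with the structure `CCOC(=O)CN(Cc1ccccc1)c1nc(Nc2ccccc2)ncc1[N+](=O)[O-]`, likewise reaches only a limit, where compound 3 gives > 100000 nM. The step of an at least 1.8-fold higher number from compound 1 to compound 2 (0.26 log units; that floor lies within the scatter) and the step of an at least 1.8-fold higher number from compound 1 to compound 3 (0.26 log units; that floor lies within the scatter) both alter the amino side of the shared core, and both end at the limit of > 100000 nM in this assay, at which 2 of the 3 values shown sit.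

Compound 4, with the structure `CCOC(=O)CNc1nc(Nc2ccc(OC)cc2)ncc1[N+](=O)[O-]`, changes a different part of compound 1: methoxy in place of hydrogen on an aromatic carbon. Within the data shown here, neither measured step touches this phenyl ring, so no measured step bears directly on this change. With nothing to point in either direction, the expected step from compound 1 to compound 4 is small. The expected step is a 1.1-fold lower number from compound 1 to compound 4 (0.04 log units; within the scatter), which amounts to no change beyond the scatter. Compound 4 is therefore expected to give 50000 nM, with a range from 20000 nM to 150000 nM.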

Compound 4, half-maximal inhibitory concentration: 32600 nM
Estimate against measurement, compound 4: 1.5-fold (0.19 log units) above; the range from low to high includes it.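

Compound 4 is the first compound shown with a change on the phenyl ring rather than on the amino side of the shared core, and in this assay that change gives a 1.7-fold lower number from compound 1 to compound 4 (0.22 log units; within the scatter). Methoxy on this aromatic carbon, para to a large group, therefore leaves the reading where the scatter alone could place it, so this single comparison shows that the ring can carry the added group without a change beyond the scatter. This also sets the ring apart from the amino side, where both changes shown end not in a number but in a limit of the assay, one for compound 2 and one for compound 3: the limit of > 100000 nM in this assay, at which 2 of the 4 values shown sit.

From the compounds shown here alone, one group at one place on the ring says little about the ring as a whole, so it remains open whether a chlorine atom, an amine or a carboxylic acid at the same carbon would move the number beyond the scatter, or whether methoxy on another carbon of the ring would do so. Going by these compounds, on the other side of the molecule, it is also open how a carboxylic acid in place of the ethyl ester, or a longer chain between the amino nitrogen and the ester, would read.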